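This account rests on a few compounds, and the source may have more. Where it says the series, first, only, none or still open, it means among the compounds named here.

Measured in a functional assay on HeLa cells (Homo sapiens) for cytotoxicity, read by MTT assay, with a stated time of 72 h; on this read-out lower numbers stand for stronger inhibition and higher numbers for weaker inhibition:
compound 1 `CC(=O)N(/N=N/c1ccc([N+](=O)[O-])cc1Cl)c1ccc([N+](=O)[O-])cc1Cl` gives 630 nM
compound 2 `O=C(c1ccccc1)N(/N=N/c1ccc([N+](=O)[O-])cc1Cl)c1ccc([N+](=O)[O-])cc1Cl` gives 590 nM
compound 3 `O=C(CCl)N(/N=N/c1ccc([N+](=O)[O-])cc1Cl)c1ccc([N+](=O)[O-])cc1Cl` gives 550 nM

Compound 3 has the lowest of the three numbers, but the gaps to the other two, a 1.1-fold lower number from compound 2 to compound 3 (0.03 log units; within the scatter) and a 1.1-fold lower number from compound 1 to compound 3 (0.06 log units; within the scatter), are both within the scatter, so no order among the three can be read.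

Compound 4 `COC(=O)N(/N=N/c1ccc([N+](=O)[O-])cc1Cl)c1ccc([N+](=O)[O-])cc1Cl` differs from compound 3 by methoxy in place of chloromethyl on a carbonyl carbon. All three measured steps change the substituent on this same carbonyl carbon: a 1.1-fold lower number from compound 1 to compound 2 (0.03 log units; within the scatter), a 1.1-fold lower number from compound 1 to compound 3 (0.06 log units; within the scatter) and a 1.1-fold lower number from compound 2 to compound 3 (0.03 log units; within the scatter). Methyl, phenyl and chloromethyl on the carbonyl thus give numbers within the scatter of one another, which suggests this position tolerates varied groups without a change in this assay. Methoxy has no precedent among the measured compounds, so the range is set wide. The expected step is a 1.1-fold higher number from compound 3 to compound 4 (0.04 log units; within the scatter), no change beyond the scatter. For compound 4 the estimate is 600 nM, with a range of 300 nM to 1300 nM.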

Compound 4, half-maximal inhibitory concentration: 980 nM
Compound 4: the middle estimate sits 1.6-fold (0.21 log units) below what was measured; measured number inside the range.
By their numbers in this assay, from the lowest: compounds 3, 2, 1 and 4 (each within the scatter of the next).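

Methoxy on the carbonyl carbon, whose other neighbour is the amide-type nitrogen, stays within the scatter of the other three groups in this assay (a 1.8-fold higher number from compound 3 to compound 4 (0.25 log units; within the scatter)) and (a 1.7-fold higher number from compound 2 to compound 4 (0.22 log units; within the scatter)) and (a 1.6-fold higher number from compound 1 to compound 4 (0.19 log units; within the scatter)). The tolerance seen with methyl, phenyl and chloromethyl therefore extends to a group that carries a hydrogen-bond acceptor and joins the carbonyl carbon through oxygen rather than carbon, so no order can be read among the four compounds. No measurement available here bears on this result.

Still open, from the compounds shown here alone, is whether an amine or a longer chain ending in a carboxylic acid on this carbonyl carbon would also stay within the scatter. Open too, going by these compounds, is whether changes to the shared core are tolerated in the same way.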